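From Phenoxy to Phenyl on a Carbonyl Carbon

This account rests on a few compounds, and the source may have more. Where it says the series, first, only, none or still open, it means among the compounds named here.

In a functional assay on MKN-45 cells (Homo sapiens) for cytotoxicity (a higher number here means a weaker inhibitor, a lower number a stronger inhibitor), compound 1 `COc1ccc(S(=O)(=O)N2CCc3cccc(NC(=O)Oc4ccccc4)c32)cc1` gives > 10000 nM, and this is a limit of the assay, not a number. Compound 2 `COc1ccc(S(=O)(=O)N2CCc3cc(Br)cc(NC(=O)c4ccco4)c32)cc1`, by contrast, reaches a measured 78 nM in this assay. Compound 3 `COc1ccc(S(=O)(=O)N2CCc3cccc(NC(=O)c4ccccc4)c32)cc1` has phenyl in place of phenoxy on a carbonyl carbon. Among the compounds with values here, no measured step covers this change, so the only guide is compound 2 at 78 nM, which suggests that compound 3 may also give a number. An expected step of an at least 6.6-fold lower number from compound 1 to compound 3 (0.82 log units; beyond the scatter) would run towards stronger inhibition, with its size very uncertain. The estimate for compound 3 is 1500 nM, with an expected range of 150 nM to 10000 nM.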

Compound 3, half-maximal inhibitory concentration: 250 nM
Beside the measured number, compound 3's estimate is 6.0-fold (0.78 log units) above it; measured number inside the range.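

Phenyl in place of phenoxy on a carbonyl carbon, whose other neighbour is the amide-type nitrogen, brings an at least 40-fold lower number from compound 1 to compound 3 (1.60 log units; beyond the scatter) in this assay. This single change on the core of compound 1 is therefore enough to move the read-out from a limit to a measured number. The step is only a bound, because compound 1 stands at a limit of the assay and not at a number: the limit of > 10000 nM in this assay, at which 1 of the 3 values shown sits. The compounds shown leave open how a benzyl group, an anilino group or a longer chain on this carbonyl carbon would read. They also leave open whether other rings in place of phenyl would hold this value.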